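The source may report more compounds than this note shows. Statements on the series, on what has been measured and on what is new or still open speak of the compounds shown alone.

Measured compounds:
compound 1 `CCNC(=O)c1noc(-c2cc(C(C)C)c(O)cc2O)c1-c1cc(COCC(=O)OC)no1` — "not determined" (no result reported) in a functional assay on A2780 cells (Homo sapiens) for inhibition; a lower number here means a stronger inhibitor, a higher number a weaker inhibitor
compound 2 `C=CNCc1cc(-c2c(C(=O)NCC)noc2-c2cc(C(C)C)c(O)cc2O)on1` — 43 nM

Of the two compounds with a structure in hand, only compound 2 carries a number: in this assay compound 2 gives 43 nM. Compound 1 shares the same core but has no reported result, so nothing can be said about the gap between the two, and compound 2 stands alone as the single reference point here.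

Compound 3 `CCNC(=O)c1noc(-c2cc(C(C)C)c(O)cc2O)c1-c1cnn(CC)c1` is not yet measured. It departs from compound 2 by one change: 1-ethyl-1H-pyrazol-4-yl in place of 3-((vinylamino)methyl)-1,2-oxazol-5-yl on an aromatic carbon. Going by the values given here, the group that leaves is larger and brings one hydrogen-bond donor and one more hydrogen-bond acceptor than the group that enters, and no measured pair on this core shows what that kind of swap does. Without such a comparison, the step is expected to be modest and to run toward weaker inhibition, with a fair chance that it stays within the scatter. On that basis compound 3 is expected to give about 100 nM, within 30 nM to 400 nM, which means an estimated step of a 2.3-fold higher number from compound 2 to compound 3 (0.37 log units; beyond the scatter).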

Compound 3, half-maximal inhibitory concentration: 30 nM
Compound 3: the middle estimate sits 3.3-fold (0.52 log units) above what was measured; measured number inside the range.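

Setting 1-ethyl-1H-pyrazol-4-yl in place of 3-((vinylamino)methyl)-1,2-oxazol-5-yl gives the first readable comparison at this position of the shared core: in this assay the swap amounts to a 1.4-fold lower number from compound 2 to compound 3 (0.16 log units; within the scatter) and so does not separate the two compounds. The entering group has fewer heavy atoms, no hydrogen-bond donor, one hydrogen-bond acceptor fewer and no double bond outside the aromatic ring, yet for this one pair the read-out stays level, so the vinylamino side chain of compound 2 is not needed to keep inhibition in this range. Nothing available explains why these two groups read alike.

The compounds shown leave open whether a propyl or longer chain in place of the ethyl of the pyrazole, or a primary amine or a carboxylic acid carried on the ring at this position, would move the number beyond the usual scatter. A single pair also cannot separate the part played by the ring from that of its side chain, since both change together from compound 2 to compound 3.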